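A few compounds are considered here, and "the series" means these few. Any claim that something is new, unique, unknown or untested is made for them only; others in the source may bear on it.

Compound 1 `COc1ccc(Cl)cc1S(=O)(=O)Nc1cncc(C(=O)Nc2ccccc2)c1`: 310 nM
Compound 2 `COc1ccc(Cl)cc1S(=O)(=O)Nc1cncc(C(N)=O)c1`: 16 nM

For the measured compounds named here, in an assay on isolated protein for inhibition of alkaline phosphatase, tissue-nonspecific isozyme (Homo sapiens) (a higher number here means a weaker inhibitor, a lower number a stronger inhibitor), compound 2 holds the lower of the two numbers; the only measured step, a 19-fold lower number from compound 1 to compound 2 (1.29 log units; beyond the scatter), sets it apart from the other compound. Compound 3 `COC(=O)c1cncc(NS(=O)(=O)c2cc(Cl)ccc2OC)c1` differs from compound 2 by methoxy in place of amino on a carbonyl carbon. The measured step touches the same carbonyl group and shows that the substituent there matters, but it does not test the change to an ester, so its size is only a loose guide. A modest weakening is expected, a 3.1-fold higher number from compound 2 to compound 3 (0.49 log units; beyond the scatter). Compound 3 is estimated at 50 nM, range 15 nM to 160 nM.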

Compound 3, half-maximal inhibitory concentration: 65 nM
The estimate for compound 3 lay 1.3-fold (0.11 log units) below the measured number, and the stated range covers the measured number.
By their numbers in this assay, from the lowest: compound 2; then compound 3; then compound 1.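

In this assay, methoxy on the carbonyl carbon gives a 4.1-fold higher number from compound 2 to compound 3 (0.61 log units; beyond the scatter), whereas replacing anilino with the same group gives a 4.8-fold lower number from compound 1 to compound 3 (0.68 log units; beyond the scatter). The position therefore accepts an ester, and compound 3 falls between the primary amide compound 2 and the anilide compound 1. Exchanging amino for methoxy removes a hydrogen-bond donor and adds an acceptor, yet this step is modest, not large. Nothing available explains this order. Open, going by these compounds, is how a carboxylic acid, a methylamide or an ethyl ester on this carbonyl carbon would compare with compound 2 and compound 3.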